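Same swap, second core: an expectation for compound 4

A few compounds are considered here, and "the series" means these few. Any claim that something is new, unique, unknown or untested is made for them only; others in the source may bear on it.

Measured compounds:
- compound 1 `CCCCC/C=C\C/C=C\C/C=C\C/C=C\CCCC(=O)OC[C@@H]1C=CC(=O)[C@@H](CC2=CCCCC2)O1`: 35000 nM
- compound 2 `CCCCC/C=C\C/C=C\C/C=C\C/C=C\CCCC(=O)OC[C@@H]1C=CC(=O)[C@@H](C2CCCC=C2C)O1`: 5000 nM
- compound 3 `CCCCC/C=C\C/C=C\C/C=C\C/C=C\CCCC(=O)OC[C@H]1O[C@H](C2CCCC=C2C)C=CC1=O`: 1 nM

Of the compounds shown here, three have been tested in a functional assay on LFCl2A cells (Rattus norvegicus) for cytotoxicity; on this read-out higher numbers stand for weaker inhibition and lower numbers for stronger inhibition. Compound 1 `CCCCC/C=C\C/C=C\C/C=C\C/C=C\CCCC(=O)OC[C@@H]1C=CC(=O)[C@@H](CC2=CCCCC2)O1` gives 35000 nM and compound 2 `CCCCC/C=C\C/C=C\C/C=C\C/C=C\CCCC(=O)OC[C@@H]1C=CC(=O)[C@@H](C2CCCC=C2C)O1` gives 5000 nM. These two share a core and differ in one place: (cyclohex-1-en-1-yl)methyl in place of 2-methylcyclohex-2-en-1-yl on a saturated ring carbon. That change made a 7.0-fold higher number from compound 2 to compound 1 (0.85 log units; beyond the scatter).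

Compound 3 `CCCCC/C=C\C/C=C\C/C=C\C/C=C\CCCC(=O)OC[C@H]1O[C@H](C2CCCC=C2C)C=CC1=O` gives 1 nM, the lowest of the three numbers. Its core differs from the core of compound 2, but the difference between the two cores is not broken down here; the two values alone show that compound 3 sits far stronger than compound 2 and compound 1 in this assay.

Compound 4 `CCCCC/C=C\C/C=C\C/C=C\C/C=C\CCCC(=O)OC[C@H]1O[C@H](CC2=CCCCC2)C=CC1=O` has not yet been measured. It carries the same change on the core of compound 3 that turned compound 2 into compound 1: (cyclohex-1-en-1-yl)methyl in place of 2-methylcyclohex-2-en-1-yl on a saturated ring carbon. If this swap acts alike on both cores, a step about the size of a 7.0-fold higher number from compound 2 to compound 1 (0.85 log units; beyond the scatter) is expected again, so compound 4 is expected to show a 7.0-fold higher number from compound 3 to compound 4 (0.85 log units; beyond the scatter). The expectation rests on compound 2 and compound 1 alone, and the two cores have shown very different values, so the range is kept wide. Compound 4 is estimated at 7 nM, between 1.5 nM and 50 nM.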

Compound 4, half-maximal inhibitory concentration: 7000 nM
For compound 4 the middle estimate is 1000-fold (3.00 log units) below the measured one; measured number outside the range, above it.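

In this assay, putting (cyclohex-1-en-1-yl)methyl in place of 2-methylcyclohex-2-en-1-yl on the core of compound 3 gives a 7000-fold higher number from compound 3 to compound 4 (3.85 log units; beyond the scatter), so on this core the swap turns a very strong compound into a weak one. The change raises the number on both cores, but the size of the step does not carry over from one core to the other: the same change on two cores in this assay, a 7.0-fold higher number (0.85 log units; beyond the scatter) from compound 2 to compound 1 and a 7000-fold higher number (3.85 log units; beyond the scatter) from compound 3 to compound 4, 1000-fold (3.00 log units) apart, beyond the scatter of two such steps. Among the compounds shown here, this shows that, in this series, a step measured on one core cannot simply be added to the value of a compound on another core, but with only two pairs it does not show why the two steps differ, nor which feature of the cores is responsible, nor how the change would behave on any third core.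

The compounds shown leave open how other groups on the same saturated ring carbon, such as a plain cyclohexyl or a phenyl ring, would behave on each of the two cores. They also leave open what the long ester chain contributes on either core, for instance whether a shorter chain or a free hydroxyl group in its place would keep the low number of compound 3.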